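Tertiary Amide Replaces the tert-Butyl Urea Terminus

A few compounds are considered here, and "the series" means these few. Any claim that something is new, unique, unknown or untested is made for them only; others in the source may bear on it.

Compound 1 `Cc1c(C(C)C)c(=O)on1C(=O)NC(C)(C)C` was examined in an assay (strain Wistar) for inhibition of Hormone-sensitive lipase (Rattus norvegicus), read by spectrophotometry; a higher number here means a weaker inhibitor, a lower number a stronger inhibitor. Compound 1 reaches only the limit of > 1000 nM there, so no number stands for it. Compound 2 `Cc1c(C(C)C)c(=O)on1C(=O)Nc1ccccc1` carries phenyl in place of tert-butyl on an amide-type nitrogen, and in this assay compound 2 likewise sits at the limit of > 1000 nM. The step that the two limits leave unreadable from compound 1 to compound 2 therefore cannot be read, because the limit of > 1000 nM in this assay, at which 2 of the 2 values shown sit, holds both values. Compound 3 `Cc1c(C(C)C)c(=O)on1C(=O)N(C)CCC#N` differs from compound 1 by (2-cyanoethyl)(methyl)amino in place of (tert-butyl)amino on a carbonyl carbon. Among the measured compounds shown here, the only measured step touches the same carbonyl carbon but yields no size, so no direction beyond the scatter can be foreseen. Compound 3 is therefore expected near 3000 nM, between 800 nM and 20000 nM, most probably once more as a limit. The step that the limit leaves unreadable from compound 1 to compound 3 is expected to be small.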

Compound 3, half-maximal inhibitory concentration: > 1000 nM
Compound 3: a limit, no number; the forecaster's own chance of this, stated with the estimate: 70%; the middle value is on the limit's open side.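

No step can be read between compound 1 and compound 3, because both remain limits rather than numbers: the limit of > 1000 nM in this assay, at which 3 of the 3 values shown sit.

The compounds shown leave open how strongly compound 1, compound 2 and compound 3 inhibit the enzyme, and whether (2-cyanoethyl)(methyl)amino in place of (tert-butyl)amino changes that inhibition at all.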